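Furan-2-yl in place of pyridin-4-yl: working notes

The compounds below may be only part of what the source reports. "The series", "measured", "known", "first", "only" and "open" are said of these compounds alone.

Among the measured compounds shown here, in an ADME assay on Vero cells (Chlorocebus sabaeus) for cytotoxicity, read by MTT assay (on this read-out higher numbers stand for weaker inhibition and lower numbers for stronger inhibition), compound 2 `C=CCOc1cc(OC)c(C(=O)/C=C/c2ccncc2)c(OCC=C)c1` gives 2800 nM, the lower of the two numbers so far, and compound 1 `C=CCOc1cc(OC)c(C(=O)/C=C/c2ccccc2F)c(OCC=C)c1` gives 16300 nM. For the measured compounds named here, the only measured step is a 5.8-fold lower number from compound 1 to compound 2 (0.77 log units; beyond the scatter), with pyridin-4-yl in place of 2-fluorophenyl; it is modest but beyond the scatter.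

Compound 3 `C=CCOc1cc(OC)c(C(=O)/C=C/c2ccco2)c(OCC=C)c1` is not yet measured. It carries furan-2-yl in place of pyridin-4-yl on a double-bonded chain carbon bound to a double-bonded chain carbon.

The measured step bears on this change only indirectly. Going by the values given here, it falls at the same place, so it indicates how far a swap there can move the number in this assay, but no furan-2-yl compound has a value yet. Since compound 2 at 2800 nM holds the lower number and compound 1 at 16300 nM the only other, a landing between them is the working expectation. The expected change is modest and upward: a 2.5-fold higher number from compound 2 to compound 3 (0.40 log units; beyond the scatter). For compound 3 the estimated value is 7000 nM, with an expected range of 2500 nM to 20000 nM.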

Compound 3, half-maximal inhibitory concentration: 191000 nM
Estimate against measurement, compound 3: 27-fold (1.44 log units) below; the measured number lies above the stated range.
By their numbers in this assay, from the lowest: compound 2; then compound 1; then compound 3.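

In this assay, among the compounds shown here, the place on a double-bonded chain carbon bound to a double-bonded chain carbon proves far more sensitive than the one earlier step could show: there is a 68-fold higher number from compound 2 to compound 3 (1.83 log units; beyond the scatter), and a 12-fold higher number from compound 1 to compound 3 (1.07 log units; beyond the scatter). Furan-2-yl therefore falls outside the span set by the two six-membered aromatic rings and gives the weakest inhibition of the three, so that span does not bound what a swap at this place can do. The hydrogen-bond donor and acceptor counts are the same for the leaving pyridin-4-yl and the entering furan-2-yl, so those counts alone do not track the large step from one to the other.

Nothing on hand gives a measured reason for the size of this step. For the compounds shown here, with only one five-membered ring in the set, ring size cannot be separated from the change of hetero atom, and it remains open whether a thiophen-2-yl ring, with sulfur as its hetero atom, would stay near the high number of compound 3 191000 nM or return towards the six-membered examples.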